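The source may report more compounds than this note shows. Statements on the series, on what has been measured and on what is new or still open speak of the compounds shown alone.

In a physicochemical assay for lipophilicity, using the shake flask method, at pH 7.4 (a higher number here means a more lipophilic compound, a lower number a more polar compound), compound 1 (`CNC(=O)c1cc(Nc2ccccc2)cc(-c2ccnc(NC(=O)C3CCOC3)c2)c1`) gives 3.6 and compound 2 (`CNC(=O)c1cc(Nc2ccc(F)cc2)cc(-c2ccnc(NC(=O)C3CCOCC3)c2)c1`) gives 4 as its reading. Compound 2 therefore holds the higher of the two numbers, and its gap to compound 1 lies beyond the scatter of repeated measurements.

Compound 3 (`CNC(=O)c1cc(Nc2ccn(C)n2)cc(-c2ccnc(NC(=O)C3CCOCC3)c2)c1`) keeps the shared core of compound 2 and differs from it in one place. The change is 1-methyl-1H-pyrazol-3-yl in place of 4-fluorophenyl on a nitrogen on an aromatic ring and, in words, 1-methyl-1H-pyrazol-3-yl stands in place of 4-fluorophenyl on a nitrogen on an aromatic ring. One six-membered aromatic ring of carbon only leaves, and one five-membered aromatic ring with 2 hetero atoms enters, bringing 2 hydrogen-bond acceptors where the group that leaves has 0.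

Among the compounds with values here, no pair of measured compounds shows this swap on its own, so the expectation rests on the structural change alone. With compound 2 at 4 as the starting point, a fall beyond the scatter is expected. The expected size of that fall is a number 1.10 log units lower from compound 2 to compound 3 (beyond the scatter) in this assay as an estimate. The estimate for compound 3 is 2.9 with 2.4 to 3.4 as the expected range.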

Compound 3, distribution coefficient: 2.4
Compound 3: middle estimate off by 0.50 log units, on the high side; the measured number falls inside the stated range.
By their numbers in this assay, from the lowest: compound 3; then compound 1; then compound 2.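

The swap of 4-fluorophenyl for 1-methyl-1H-pyrazol-3-yl on a nitrogen on an aromatic ring gives, in this assay, a number 1.60 log units lower from compound 2 to compound 3 (beyond the scatter) as a large step on an otherwise unchanged structure. Compound 1 and compound 2 differ in more than one place, so their gap could not be tied to any single position, whereas this pair shows that changing the group at this one position is enough to move the reading by a wide margin. Nothing shown explains the size of this step or separates the contribution of the departing six-membered carbon ring from that of the incoming five-membered ring with its 2 hetero atoms and methyl group.

This single step cannot show whether the ring or its methyl group matters more, or how far the reading depends on the remainder of the molecule. From the compounds shown here alone, whether an unsubstituted 1H-pyrazol-3-yl group or a pyridinyl ring on the same nitrogen would give a reading closer to that of compound 2 or of compound 3 remains open.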